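The source may hold more compounds than are shown below. What is called first, only, known or untested is meant among the compounds shown, and "the series" means these compounds.

Three compounds have been measured in a functional assay on HeLa cells (Homo sapiens) for inhibition, read by sulforhodamine B assay, with a stated time of 48 h; a lower number here means a stronger inhibitor of growth, a higher number a weaker inhibitor of growth:

Compound 1, `COC(=O)[C@@]1(C)CCC=C2[C@@H]1CC[C@@H](C)[C@]2(C)Cc1c(C)[nH]c2ccc(Br)cc12`, gives 11000 nM.
Compound 2, `COC(=O)[C@@]1(C)CCC=C2[C@@H]1CC[C@@H](C)[C@]2(C)Cc1c(C)[nH]c2ccc(OC)cc12`, gives 12000 nM.
Compound 3, `COC(=O)[C@@]1(C)CC[C@@H]2C3=C1CC[C@@H](C)[C@]3(C)Cc1c2[nH]c2ccc(Br)cc12`, gives 14000 nM.

Compound 1 and compound 2 share one core and differ in a single place: methoxy in place of bromo on an aromatic carbon. This change produced a 1.1-fold higher number from compound 1 to compound 2 (0.04 log units; within the scatter), so the two values sit within the scatter of each other and no order between them can be read.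

Compound 3 carries a different core; the difference between the core of compound 1 and the core of compound 3 is not broken down here. Its value in this assay lies within the scatter of both compound 1 and compound 2.

Compound 4, `COC(=O)[C@@]1(C)CC[C@@H]2C3=C1CC[C@@H](C)[C@]3(C)Cc1c2[nH]c2ccc(OC)cc12`, is not yet measured. It stands to compound 3 as compound 2 stands to compound 1: methoxy in place of bromo on an aromatic carbon. The place is described in almost the same words for both pairs, except that in compound 1 the six-membered aromatic ring of carbon only is part of a fused or bridged system of two rings, whereas in compound 3 it is part of a fused or bridged system of five rings; the change is therefore the same kind of change, not the same change.

Because the earlier step was a 1.1-fold higher number from compound 1 to compound 2 (0.04 log units; within the scatter), the step from compound 3 to compound 4 is expected to be similarly small, a 1.1-fold higher number from compound 3 to compound 4 (0.03 log units; within the scatter). On that basis compound 4 is estimated at 15000 nM in this assay, most likely between 7000 nM and 32000 nM.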

Compound 4, concentration for 50% growth inhibition: 3900 nM
Beside the measured number, compound 4's estimate is 3.8-fold (0.59 log units) above it, and the stated range ends above it.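

In this assay, methoxy in place of bromo on an aromatic carbon gave a 3.6-fold lower number from compound 3 to compound 4 (0.56 log units; beyond the scatter), a modest step on the core of compound 3, whereas the same kind of change left no readable order on the core of compound 1. The change therefore did not carry over from one core to the other with the same size: the same change on two cores in this assay, a 1.1-fold higher number (0.04 log units; within the scatter) from compound 1 to compound 2 and a 3.6-fold lower number (0.56 log units; beyond the scatter) from compound 3 to compound 4, 3.9-fold (0.59 log units) apart, beyond the scatter of two such steps This shows that, in these two pairs, the result of the exchange depended on the core that carried it, so a step read on one core was a poor guide to the other; it does not show which feature of the cores is responsible, and two pairs with one read-out establish no rule for the wider series.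

The compounds shown leave open whether other groups at that aromatic carbon, such as a hydroxyl, an amine or a longer ether chain like ethoxy, would also separate from bromo on the core of compound 3 but not on the core of compound 1. They also leave open how a carboxylic acid or an amide in place of the methyl ester would behave on either core.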